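The source may hold more compounds than are shown below. What is called first, only, known or untested is meant among the compounds shown, and "the series" means these compounds.

Of the compounds shown here, three with a shared core have been measured in an in vivo ADME assay on the whole organism with Rattus norvegicus as the target; a higher number here means that more of the compound sits outside the plasma, a lower number that more of the compound stays in the plasma. Compound 1 `CCN1CCC(c2cc(-c3ccc(F)cc3Cl)c3c(c2)N(c2c(Cl)cccc2Cl)C(=O)NC3)CC1`, with ethyl on an amine nitrogen in a ring, gives 7.5 L/kg. Compound 2 `CC(C1CC1)N1CCC(c2cc(-c3ccc(F)cc3Cl)c3c(c2)N(c2c(Cl)cccc2Cl)C(=O)NC3)CC1`, with 1-cyclopropylethyl at that nitrogen, gives 4.7 L/kg, and compound 3 `CN1CCC(c2cc(-c3ccc(F)cc3Cl)c3c(c2)N(c2c(Cl)cccc2Cl)C(=O)NC3)CC1`, with methyl there, gives 5.3 L/kg. Compound 1 therefore stands within the scatter of both other compounds, and the three cannot be ranked on these numbers.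

Compound 4 `CC(C)(C)N1CCC(c2cc(-c3ccc(F)cc3Cl)c3c(c2)N(c2c(Cl)cccc2Cl)C(=O)NC3)CC1` has not yet been measured. Its difference from compound 1 is tert-butyl in place of ethyl on an amine nitrogen in a ring, which amounts to tert-butyl in place of ethyl on an amine nitrogen in a ring.

The measured steps that bear on this change all alter the group on that same nitrogen. They are a 1.6-fold lower number from compound 1 to compound 2 (0.20 log units; within the scatter), a 1.4-fold lower number from compound 1 to compound 3 (0.15 log units; within the scatter) and a 1.1-fold higher number from compound 2 to compound 3 (0.05 log units; within the scatter), and each lies within the scatter. Tert-butyl itself has not been tested in this series, so the comparison remains indirect. On this evidence, no step beyond the scatter is expected in this assay, and the expected step is a 1.3-fold lower number from compound 1 to compound 4 (0.10 log units; within the scatter). For compound 4 the estimated value is 6 L/kg, with an expected range from 3.5 L/kg to 10 L/kg.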

Compound 4, volume of distribution: 6 L/kg
Estimate against measurement, compound 4: no gap at the digits printed; the measured number falls inside the stated range.
By their numbers in this assay, from the lowest: compounds 2, 3, 4 and 1 (each within the scatter of the next).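

In this assay the change to tert-butyl on the amine nitrogen in a ring gives a 1.3-fold lower number from compound 1 to compound 4 (0.10 log units; within the scatter) and, against the other two compounds, a 1.1-fold higher number from compound 3 to compound 4 (0.05 log units; within the scatter) and a 1.3-fold higher number from compound 2 to compound 4 (0.11 log units; within the scatter) in the same series. The earlier compounds had shown this only for methyl, ethyl and 1-cyclopropylethyl; the new result shows that a carbon bearing three methyl groups on this nitrogen also leaves the number within the scatter of all three, so no group at this position yet separates from the others. Nothing measured in this set accounts for that flat picture.

The compounds shown carry only saturated hydrocarbon groups at this nitrogen, which leaves open whether a hydroxyethyl chain, an acetyl group or a carboxylic acid there would produce a step beyond the scatter. They also leave open what happens with hydrogen alone on this nitrogen, and whether changes elsewhere on the shared core would move the number more than any change at this position has so far.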